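Propyl in Place of Benzylsulfanyl: From Compound 2 to Compound 4

The source may hold more compounds than are shown below. What is called first, only, known or untested is meant among the compounds shown, and "the series" means these compounds.

Of the compounds shown here, three have been measured in a functional assay (spleen, spleen) for activation, with Mus musculus as the target; on this read-out higher numbers stand for an effect only at larger amounts of compound and lower numbers for an effect already at smaller amounts. Compound 1 `CCCCOc1nc(N)c2[nH]c(=O)n(Cc3ccccc3)c2n1` gives 0.001 uM, compound 2 `Nc1nc(SCc2ccccc2)nc2c1nc(O)n2Cc1ccccc1` gives 0.1 uM, and compound 3 `Cc1ccc(Cn2c(O)nc3c(N)ncnc32)cc1` gives 10 uM. Compound 2 thus stands second highest of the three numbers; its nearest neighbour is compound 1 with a lower number, and compound 3 lies furthest with a higher number, both gaps beyond the scatter.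

Compound 4 `CCCc1nc(N)c2nc(O)n(Cc3ccccc3)c2n1` differs from compound 2 in one place: propyl in place of benzylsulfanyl on an aromatic carbon. Going by the values given here, no measured pair shows this change. A modest move toward a lower number is expected, because compound 1, which carries a different group in the same place, gives 0.001 uM. The step from compound 2 to compound 4 is estimated at a 3.3-fold lower number from compound 2 to compound 4 (0.52 log units; beyond the scatter). Compound 4 is expected to give 0.03 uM, within a range from 0.003 uM to 0.3 uM.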

Compound 4, minimum effective concentration: 1 uM
For compound 4 the middle estimate is 33-fold (1.52 log units) below the measured one; measured number above the stated range.
By their numbers in this assay, from the lowest: compound 1; then compound 2; then compound 4; then compound 3.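

In this assay, the aromatic carbon between two ring nitrogen atoms proves sensitive to this change: propyl in place of benzylsulfanyl gives a 10-fold higher number from compound 2 to compound 4 (1.00 log units; beyond the scatter). The result links the group with a six-membered aromatic ring and sulfur to an effect at smaller amounts than propyl, though it cannot separate these features. No measurement shown gives a reason for this shift.

Still open, going by these compounds, is whether the sulfur, the ring or the chain length governs the step. Methylsulfanyl, a benzyl group or a longer chain such as pentyl at this place would help separate them.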